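A few compounds are considered here, and "the series" means these few. Any claim that something is new, unique, unknown or untested is made for them only; others in the source may bear on it.

Compound 3 `Nc1nc2c(c(-c3ccoc3)cn2[C@@H]2O[C@H](CO)[C@@H](O)[C@H]2O)c(=O)[nH]1` and compound 1 `Nc1nc2c(c(-c3cccs3)cn2[C@@H]2O[C@H](CO)[C@@H](O)[C@H]2O)c(=O)[nH]1` share one core, while compound 2 `CSc1ncnc2c1c(-c1ccoc1)cn2[C@@H]1O[C@H](CO)[C@@H](O)[C@H]1O` and compound 4 `CSc1ncnc2c1c(-c1cccs1)cn2[C@@H]1O[C@H](CO)[C@@H](O)[C@H]1O` share another; how the two cores differ is not broken down here. In a functional assay on CEM-DNR-bulk cells (Homo sapiens), read by MTT assay, with a stated time of 72 h (on this read-out higher numbers stand for weaker inhibition and lower numbers for stronger inhibition), compound 3 gives 15000 nM. Compound 1 reaches only the limit of the assay, > 20000 nM. Compound 2 likewise reaches only the limit, > 20000 nM. The change from compound 3 to compound 1 is thiophen-2-yl in place of furan-3-yl on an aromatic carbon, and it made an at least 1.3-fold higher number from compound 3 to compound 1 (0.12 log units; that floor lies within the scatter), a floor set by the limit of > 20000 nM in this assay, at which 2 of the 3 values shown sit. The same change, (thiophen-2-yl in place of furan-3-yl on an aromatic carbon), leads from compound 2 to compound 4, at a place described in identical words. Compound 2 already sits at the limit, so the step expected from compound 2 to compound 4 is a step that the limit leaves unreadable from compound 2 to compound 4, resting on an at least 1.3-fold higher number from compound 3 to compound 1 (0.12 log units; that floor lies within the scatter). Compound 4 is therefore estimated at 30000 nM, most likely reported again only as a limit.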

Compound 4, half-maximal inhibitory concentration: > 20000 nM
Compound 4 was reported as a limit; the forecaster's own chance of this, stated with the estimate: 85%; the middle value is on the limit's open side.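

No new step can be read between compound 2 and compound 4, because each of them stops at a limit of the assay: the limit of > 20000 nM in this assay, at which 3 of the 4 values shown sit.

On these data alone, whether thiophen-2-yl and furan-3-yl differ at all on the core of compound 2 stays open.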